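Exchanging One Ring Group for Another

The source may hold more compounds than are shown below. What is called first, only, known or untested is meant among the compounds shown, and "the series" means these compounds.

For the measured compounds named here, in a functional assay on HCT-116 cells (Homo sapiens) for cytotoxicity, read by MTT assay, with a stated time of 72 h (on this read-out lower numbers stand for stronger inhibition and higher numbers for weaker inhibition), compound 1 (`COc1ncc(-c2ccc3nc(NC(=O)NCC(=O)N4CCCCC4)nn3c2)cc1NS(=O)(=O)c1ccc(F)cc1`) gives 130 nM and compound 2 (`COc1ncc(-c2ccc3nc(NC(=O)NCCN4CCCCC4)nn3c2)cc1NS(=O)(=O)c1ccc(F)cc1`) gives 150 nM, so compound 2 stands level with the only other measured number. Compound 3 (`COc1ncc(-c2ccc3nc(NC(=O)NCC(=O)N4CCCC4)nn3c2)cc1NS(=O)(=O)c1ccc(F)cc1`) carries (pyrrolidin-1-yl)carbonyl in place of (piperidin-1-yl)methyl on a saturated chain carbon bound to an amide-type nitrogen. Going by the values given here, the one measured step at this place, a 1.2-fold higher number from compound 1 to compound 2 (0.06 log units; within the scatter), put (piperidin-1-yl)methyl in place of (piperidin-1-yl)carbonyl. Among the compounds with values here, no measured step tests the five-membered ring, so no change beyond the scatter is expected in this assay. The expected step is a 1.1-fold lower number from compound 2 to compound 3 (0.05 log units; within the scatter). For compound 3 the estimated value is 135 nM, with an expected range of 55 nM to 330 nM.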

Compound 3, half-maximal inhibitory concentration: 140 nM
For compound 3 the middle estimate is 1.0-fold (0.02 log units) below the measured one; the range from low to high includes it.
By their numbers in this assay, from the lowest: compounds 1, 3 and 2 (each within the scatter of the next).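

In this assay, pyrrolidin-1-yl in place of piperidin-1-yl on a carbonyl carbon gives a 1.1-fold higher number from compound 1 to compound 3 (0.03 log units; within the scatter) and thus isolates the ring change that the earlier pair did not test: here, the five-membered ring and the six-membered ring cannot be told apart. Changing the ring and the linking group together gives a 1.1-fold lower number from compound 2 to compound 3 (0.03 log units; within the scatter) and also stays within the usual scatter. No measured evidence bears on this result.

As far as these compounds go, whether a morpholine ring, a dimethylamino group or an azetidine ring would also fit at this place remains open. So does the effect of a longer chain.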